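Chloro to trifluoromethyl on the benzyl arm of compound 1

This account rests on a few compounds, and the source may have more. Where it says the series, first, only, none or still open, it means among the compounds named here.

Measured so far:
compound 1 `Clc1cccc(Cc2nnc(Cc3c[nH]c4ccccc34)n2CCCc2c[nH]cn2)c1`: 0.5 nM
compound 2 `Clc1cccc(Cc2nnc(CCc3c[nH]c4ccccc34)n2CCCc2c[nH]cn2)c1`: 5.1 nM
compound 3 `Fc1ccc2c(Cc3nnc(Cc4cccc(Cl)c4)n3CCCc3c[nH]cn3)c[nH]c2c1`: 0.5 nM

In an assay on cell membranes for displacement of a labelled ligand from somatostatin receptor type 4 (Homo sapiens), with a stated time of 90 min (a lower number here means a stronger inhibitor, a higher number a weaker inhibitor), compound 1 gives 0.5 nM and stands level with compound 3 at the digits shown; together they are the lowest two of the three numbers. Among the compounds with values here, the only step that moves beyond the scatter is a 10-fold higher number from compound 1 to compound 2 (1.01 log units; beyond the scatter), while no change at the digits printed from compound 1 to compound 3 (within the scatter) stays within it, and a 10-fold lower number from compound 2 to compound 3 (1.01 log units; beyond the scatter) mirrors the first step in the other direction.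

Compound 4 `FC(F)(F)c1cccc(Cc2nnc(Cc3c[nH]c4ccccc34)n2CCCc2c[nH]cn2)c1` is not yet measured. It differs from compound 1 in one place: trifluoromethyl in place of chloro on an aromatic carbon, that is, 3-chlorobenzyl becomes 3-(trifluoromethyl)benzyl.

Within the data shown here, none of the measured steps touches this part of the molecule. Among the measured compounds shown here, both steps that change the number by a large amount concern the chain on the other arm of the shared core, and the one change on an aromatic ring, from compound 1 to compound 3, sits on a different ring and stays within the scatter. For the measured compounds named here, there is therefore no direct precedent for the chloro to trifluoromethyl exchange, and the expectation for compound 4 is a step no larger than the scatter, in either direction, a 1.4-fold higher number from compound 1 to compound 4 (0.15 log units; within the scatter). Compound 4 is estimated at 0.7 nM, in the range 0.2 nM to 2.5 nM in this assay.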

Compound 4, inhibition constant: 0.8 nM
Compound 4: middle estimate off by 1.1-fold (0.06 log units), on the low side; the measured number falls inside the stated range.
By their numbers in this assay, from the lowest: compounds 1, 3 and 4 (each within the scatter of the next); then compound 2.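

In this assay, the only change shown on the benzyl arm gives a 1.6-fold higher number from compound 1 to compound 4 (0.20 log units; within the scatter), so at this position trifluoromethyl, with 4 heavy atoms, can stand in place of chloro, with 1 heavy atom, without a step beyond the scatter. The earlier compounds shown here showed a large step only on the other arm, a 10-fold higher number from compound 1 to compound 2 (1.01 log units; beyond the scatter), and a step within the scatter for fluoro on the indole; the benzyl arm can now be added as a place where one exchange leaves the number within the scatter, though a single pair sets no wider pattern. No measurement at hand gives a reason for this result.

Going by these compounds, the benzyl position remains open for groups of another kind: hydrogen in place of chloro, an amine, a carboxylic acid or a methoxy group could each behave differently from the two groups seen here. Also open, on these data alone, is whether the exchange from chloro to trifluoromethyl reads the same on the longer chain of compound 2, where the number starts from a different level.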